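Compound 1 to Compound 4: A Different Aryl Group

This account rests on a few compounds, and the source may have more. Where it says the series, first, only, none or still open, it means among the compounds named here.

Three measured compounds share one core and differ only in the cyclic amine at the far end of the chain that hangs from an aromatic oxygen. In a functional assay on MKN-45 cells (Homo sapiens) for inhibition, read by MTT assay, with a stated time of 72 h (on this read-out lower numbers stand for stronger inhibition and higher numbers for weaker inhibition), compound 1 `COc1cc2c(Oc3ccc(NC(=O)c4nn(-c5ccccc5C)c(=O)cc4C)cc3F)ccnc2cc1OCCCN1CCCC1` gives 760 nM, the lowest of the three numbers. Compound 2 `COc1cc2c(Oc3ccc(NC(=O)c4nn(-c5ccccc5C)c(=O)cc4C)cc3F)ccnc2cc1OCCCN1CCCCC1` gives 1310 nM in this assay, and compound 3 `COc1cc2c(Oc3ccc(NC(=O)c4nn(-c5ccccc5C)c(=O)cc4C)cc3F)ccnc2cc1OCCCN1CCN(C)CC1` gives 1630 nM. The steps are small: a 1.7-fold higher number from compound 1 to compound 2 (0.24 log units; within the scatter), a 2.1-fold higher number from compound 1 to compound 3 (0.33 log units; beyond the scatter), and a 1.2-fold higher number from compound 2 to compound 3 (0.09 log units; within the scatter). Together they show that swapping one amine for another at that end moves the number only modestly.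

Compound 4 `COc1cc2c(Oc3ccc(NC(=O)c4nn(-c5cccc(F)c5)c(=O)cc4C)cc3F)ccnc2cc1OCCCN1CCCC1` has not yet been measured. It keeps the pyrrolidin-1-yl amine of compound 1 and changes a different place: 3-fluorophenyl in place of 2-methylphenyl on an aromatic nitrogen. This aryl group sits on an aromatic nitrogen of a six-membered aromatic ring with 2 nitrogen, next to the ring nitrogen. None of the three measured steps touches this position, so they give no direct guide to its effect; they only show that the shared core tolerates small changes elsewhere. Going by the values given here, with no precedent, the expected step of a 1.3-fold higher number from compound 1 to compound 4 (0.12 log units; within the scatter) is taken to be small in size and uncertain in direction. Compound 4 is therefore estimated at 1000 nM in this assay, with a range from 300 nM to 3500 nM.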

Compound 4, half-maximal inhibitory concentration: 120 nM
For compound 4 the middle estimate is 8.3-fold (0.92 log units) above the measured one; the whole stated range lies above it.
By their numbers in this assay, from the lowest: compound 4; then compounds 1, 2 and 3 (each within the scatter of the next, the first and the last beyond it).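

The aryl group on the aromatic nitrogen turns out to be a far more sensitive place than the amine end of the chain: in this assay, 3-fluorophenyl in place of 2-methylphenyl gives a 6.3-fold lower number from compound 1 to compound 4 (0.80 log units; beyond the scatter), a larger move than the biggest amine step, a 2.1-fold higher number from compound 1 to compound 3 (0.33 log units; beyond the scatter). The simple counts do not separate the two aryl groups, since each has 7 heavy atoms, one six-membered aromatic ring of carbon only, no hydrogen-bond donors or acceptors and no net charge, so the drop comes with a swap that leaves all of these counts unchanged. Nothing available here shows why the number falls at this position.

This single step changes two things at once, the kind of group on the aryl ring (fluorine for methyl) and its place on that ring, and the compounds shown cannot pull these apart; 2-fluorophenyl, 3-methylphenyl or plain phenyl would be needed to do so. From the compounds shown here alone, it also remains open whether 3-fluorophenyl gives a similar step when paired with the piperidin-1-yl or 4-methylpiperazin-1-yl amines.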